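The compounds below may be only part of what the source reports. "The series", "measured", "known", "first", "only" and "open" are said of these compounds alone.

Of the compounds shown here, three built on one shared core have been tested in a functional assay on HuTu80 cells (Homo sapiens) for cytotoxicity, read by MTT assay, with a stated time of 72 h; a lower number here means that less compound is needed, a higher number that more compound is needed for the effect. Compound 1 `O=C1/C(=C\c2ccc(O)cc2)c2ccccc2N1c1c(Cl)cccc1Cl` gives 25 ug/mL. Compound 2 `O=C1/C(=C\c2cccc(Br)c2)c2ccccc2N1c1c(Cl)cccc1Cl` gives 7 ug/mL, and the change between them reads a 3.6-fold lower number from compound 1 to compound 2 (0.55 log units; beyond the scatter). Compound 3 `COc1ccc(/C=C2\C(=O)N(c3c(Cl)cccc3Cl)c3ccccc32)cc1` gives only a limit of the assay, > 100 ug/mL, so no exact number is known for it. Compound 3 thus sits at the limit of > 100 ug/mL in this assay, at which 1 of the 3 values shown sits, the top edge of the values shown. The steps leading into compound 3 were an at least 4.0-fold higher number from compound 1 to compound 3 (0.60 log units; beyond the scatter) and an at least 14-fold higher number from compound 2 to compound 3 (1.15 log units; beyond the scatter).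

Compound 4 `CN(C)c1ccc(/C=C2\C(=O)N(c3c(Cl)cccc3Cl)c3ccccc32)cc1` differs from compound 3 in one place: dimethylamino in place of methoxy on an aromatic carbon. Within the data shown here, no measured step swaps one group for another at this position on the same ring, so the earlier steps only show that changes to the group on this ring have shifted the number by modest to large amounts. Since compound 3 is known only as a limit, the true size of the step to compound 4 cannot be fixed. The number for compound 4 is expected to remain high, estimated at 100 ug/mL, between 30 ug/mL and 300 ug/mL. This corresponds to an expected step of a number no higher from compound 3 to compound 4 (the limit leaves the size open).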

Compound 4, concentration for half-maximal effect: < 1 ug/mL
Compound 4 ended at the assay's limit; the forecaster's own chance of this, stated with the estimate: 60%; middle value at least 100-fold (2.00 log units) away from the limit.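

In this assay, dimethylamino in place of methoxy on an aromatic carbon para to a large group gives an at least 100-fold lower number from compound 3 to compound 4 (2.00 log units; beyond the scatter) in a single change, so this one position can span the whole range of values shown. Compound 4 also stands clear of the other two compounds, with an at least 7.0-fold lower number from compound 2 to compound 4 (0.84 log units; beyond the scatter) and an at least 25-fold lower number from compound 1 to compound 4 (1.39 log units; beyond the scatter) in the steps to it, and so it replaces compound 2 as the compound needing the least. Methyl groups on the atom bound to this ring therefore do not raise the number by themselves, although an at least 4.0-fold higher number from compound 1 to compound 3 (0.60 log units; beyond the scatter) came with the methyl added on oxygen.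

As far as these compounds go, compound 4 is known only as a limit, so the true size of these steps stays open: the limit of < 1 ug/mL in this assay, at which 1 of the 4 values shown sits. From the compounds shown here alone, whether both methyl groups are needed also remains open, and a methylamino group or a plain amino group at this place would test that.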